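The source may hold more compounds than are shown below. What is called first, only, known or untested is meant among the compounds shown, and "the series" means these compounds.

Three compounds have been measured in an assay on membranes from CHO cells for displacement of a labelled ligand from adenosine receptor A1 (Homo sapiens), read by scintillation counting, with a stated time of 60 min, tested at 1 uM; a higher number here means more inhibition at the concentration tested (going by the name of the read-out), a lower number less inhibition:

compound 1 `CCSC(=O)C1=C(C)NC(=O)NC1c1ccoc1` gives 3%
compound 2 `CC1=C(C(=O)SC(C)C)C(c2ccoc2)NC(=O)N1` gives 9%
compound 3 `CCC(CC)OC(=O)C1=C(C)NC(=O)NC1c1cccs1` gives 13%

All three numbers are small, and every gap between them lies within the usual scatter of such measurements, so the three numbers can only be called level with one another on this evidence.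

Compound 1 and compound 2 share a core and differ in one place: hydrogen in place of methyl on a saturated chain carbon bound to a saturated chain carbon and a sulfur. The step that goes with this change is a number 6 percentage points lower from compound 2 to compound 1 (within the scatter), which is within the scatter and so tells of no real movement.

Compound 3 carries a different core; how the core of compound 3 differs from the core of compound 2 is not broken down here.

Compound 4 `CCC(C)OC(=O)C1=C(C)NC(=O)NC1c1cccs1` has not yet been measured. It differs from compound 3 by the same kind of change, though not the same one: hydrogen in place of methyl on a saturated chain carbon, two bonds along the chain from an oxygen next to a carbonyl group. The place is different from the earlier case, where the methyl left a saturated chain carbon bound to a saturated chain carbon and a sulfur; here it leaves a saturated chain carbon, two bonds along the chain from an oxygen next to a carbonyl group.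

The step from compound 3 to compound 4 in this assay is expected to be a number 4 percentage points lower from compound 3 to compound 4 (within the scatter), resting on the earlier step of a number 6 percentage points lower from compound 2 to compound 1 (within the scatter), which stayed within the scatter. Compound 4 is therefore estimated to give 9%, most likely between 0% and 24%.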

Compound 4, a percentage reported as inhibition, at one concentration (the size of the read-out at that concentration, not a potency): 5%
Beside the measured number, compound 4's estimate is 4 percentage points above it; the range from low to high includes it.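

Replacing a methyl with hydrogen on a saturated chain carbon, two bonds along the chain from an oxygen next to a carbonyl group, turns pentan-3-yl into sec-butyl and goes with a number 8 percentage points lower from compound 3 to compound 4 (within the scatter) in this assay. Set beside the earlier step, the same kind of change reads alike on the two cores: the same change on two cores in this assay, a number 6 percentage points lower (within the scatter) from compound 2 to compound 1 and a number 8 percentage points lower (within the scatter) from compound 3 to compound 4, 2 percentage points apart, within the scatter of two such steps. This shows that removing the methyl produced no real movement on either core, but it does not show that the change has a real effect that carries from one core to another, since neither step rises above the noise, the methyl leaves a different place in each pair, and all the numbers are small.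

On these data alone, whether an amine, a carboxylic acid or a longer chain in place of these chains would lift the inhibition clear of the scatter remains open. Also open, as far as these compounds go, is whether exchanging methyl for hydrogen would still leave the number unmoved in this assay on a compound that shows substantial inhibition, where a real loss or gain would have room to appear.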